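From carboxy to ethoxycarbonyl on a shared core

The compounds below may be only part of what the source reports. "The series", "measured", "known", "first", "only" and "open" are said of these compounds alone.

In a functional assay on the whole organism for inhibition, with Cavia porcellus as the target (on this read-out higher numbers stand for an effect only at larger amounts of compound and lower numbers for an effect already at smaller amounts), compound 1 `COc1ccc(OCC2SCCN2C(=O)Cn2ccnc2)cc1` gives 48 mg/kg, compound 2 `COc1ccccc1OCC1SCCN1C(=O)CC(C)=O` gives 30 mg/kg and compound 3 `COc1ccccc1OCC1N(C(=O)CC(=O)O)CC[S+]1[O-]` gives 20 mg/kg. Compound 3 cannot be told apart from compound 2 within the usual scatter, while compound 1 stands clearly higher than compound 3. Compound 4 `CCOC(=O)CC(=O)N1CC[S+]([O-])C1COc1ccccc1OC` is compound 3 with carboxy changed to ethoxycarbonyl, that is, ethyl in place of hydrogen on an oxygen next to a carbonyl group. Within the data shown here, no measured pair shows this change alone, so the evidence is thin. Compound 2 carries no carboxy group and gives 30 mg/kg. In this assay the expected step is small, a 1.3-fold higher number from compound 3 to compound 4 (0.10 log units; within the scatter), and stays within the scatter. For compound 4 the estimated value is 25 mg/kg, with an expected range from 11 mg/kg to 55 mg/kg.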

Compound 4, dose for half-maximal effect: 27 mg/kg
Compound 4: middle estimate off by 1.1-fold (0.03 log units), on the low side, within the range that was stated.
By their numbers in this assay, from the lowest: compounds 3, 4, 2 and 1 (each within the scatter of the next, the first and the last beyond it).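

Ethyl in place of hydrogen on an oxygen next to a carbonyl group gives in this assay a 1.4-fold higher number from compound 3 to compound 4 (0.13 log units; within the scatter) and is now read directly for the first time. At this position, the carboxy hydrogen can therefore give way to ethyl with no change beyond the scatter in this pair. Nothing here explains why the two compounds read alike. As far as these compounds go, whether a longer chain such as butyl, or an amide made with an amine, would also fit at this position stays open.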